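Longer Ester Chains on a Shared Core and Cell Viability

The compounds below may be only part of what the source reports. "The series", "measured", "known", "first", "only" and "open" are said of these compounds alone.

Compound 1 `CCOC(=O)CCC(=O)N1CCN(CCCOc2cc3c(Nc4ccc(F)c(Cl)c4)ncnc3cc2OC)CC1` gives 70% in a functional assay on A549 cells (Homo sapiens) for cytotoxicity, read by MTT assay, with a stated time of 24 h, tested at 20 uM; a higher number here means a weaker effect of the compound at the concentration tested, a lower number a stronger effect.
Compound 2 `CCCCCCCCOC(=O)CCC(=O)N1CCN(CCCOc2cc3c(Nc4ccc(F)c(Cl)c4)ncnc3cc2OC)CC1` gives 80%.
Compound 3 `CCCCCCCCCCOC(=O)CCC(=O)N1CCN(CCCOc2cc3c(Nc4ccc(F)c(Cl)c4)ncnc3cc2OC)CC1` gives 88.2%.

Compound 3 holds the highest of the three numbers in this assay. Its nearest neighbour sits within the scatter: a number 8.2 percentage points higher from compound 2 to compound 3 (within the scatter). The widest gap, however, lies beyond it: a number 18.2 percentage points higher from compound 1 to compound 3 (beyond the scatter). Compound 4 `CCCCCCCCCCCCCCCCOC(=O)CCC(=O)N1CCN(CCCOc2cc3c(Nc4ccc(F)c(Cl)c4)ncnc3cc2OC)CC1` continues the same line of change, differing from compound 3 by hexyl in place of hydrogen on a saturated chain carbon, ten or more bonds along the chain from an oxygen next to a carbonyl group.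

Going by the values given here, two measured steps bear on this one, both lengthening the ester chain: a number 10 percentage points higher from compound 1 to compound 2 (within the scatter) and a number 8.2 percentage points higher from compound 2 to compound 3 (within the scatter). Each alone stayed within the scatter, yet together they summed to a modest rise. A further lengthening of the same kind is therefore expected to nudge the number in this assay upward again, though the room left above compound 3 is small, so the expected step is a number 4.8 percentage points higher from compound 3 to compound 4 (within the scatter), likely within the scatter. Compound 4 is estimated to give 93% in this assay, with a range from 83% to 103%.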

Compound 4, a percentage reported as activity, at one concentration (the size of the read-out at that concentration, not a potency): 91.7%
The estimate for compound 4 lay 1.3 percentage points above the measured number; the range from low to high includes it.
By their numbers in this assay, from the lowest: compounds 1, 2, 3 and 4 (each within the scatter of the next, the first and the last beyond it).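

Read on a saturated chain carbon, hexyl in place of hydrogen gives a number 3.5 percentage points higher from compound 3 to compound 4 (within the scatter) in this assay, and the same change reads alike on the two pairs that carry it: the same change on two cores in this assay, a number 10 percentage points higher (within the scatter) from compound 1 to compound 2 and a number 3.5 percentage points higher (within the scatter) from compound 3 to compound 4, 6.5 percentage points apart, within the scatter of two such steps

Octyl in place of hydrogen, now at eight bonds along the chain, gives a number 11.7 percentage points higher from compound 2 to compound 4 (beyond the scatter), so a modest rise also appears on a second pair of compounds, again in agreement with the first: the same change on two cores in this assay, a number 18.2 percentage points higher (beyond the scatter) from compound 1 to compound 3 and a number 11.7 percentage points higher (beyond the scatter) from compound 2 to compound 4, 6.5 percentage points apart, within the scatter of two such steps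

The compounds shown leave open what a longer chain, or a carboxylic acid in place of the ester, would give in this assay. Going by these compounds alone, with a single tested concentration, they also give no potency for any member of the series.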